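Proof-of-concept notes on a small benzofuran-type series

The compounds below may be only part of what the source reports. "The series", "measured", "known", "first", "only" and "open" are said of these compounds alone.

Measured so far:
compound 1 `COc1cc(OCc2cccc(COc3ccccc3)c2)c2cc(-c3cn4nc(OC)sc4n3)oc2c1` — 600 nM
compound 2 `COc1nn2cc(-c3cc4c(OC)cccc4o3)nc2s1` — 1300 nM

In an assay on a cell-free system (plasma) for antagonist activity at proteinase-activated receptor 4 (Homo sapiens), with a stated time of 5 min, in the presence of a further agent that is not named here (on this read-out higher numbers stand for weaker inhibition and lower numbers for stronger inhibition), compound 1 gives 600 nM, the lowest number of the two shown. Compound 2 gives 1300 nM, a higher number, and the gap between the two lies beyond the usual scatter. Within the data shown here, no pair of measured compounds differs in a single place, so no step has yet been quantified.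

Compound 3 `COc1cc(OCc2cccc(C#N)c2)c2cc(-c3cn4nc(OC)sc4n3)oc2c1` has not been measured. It differs from compound 1 in one place: cyano in place of phenoxymethyl on an aromatic carbon. Most of the outer part of the side chain in compound 1 is thereby removed and replaced by a much smaller group.

With nothing measured for this kind of change, the expectation rests only on the two numbers at hand. Compound 2, which carries no side chain of this type at all, gives 1300 nM, a higher number than compound 1; on that basis a shortening of the side chain is expected to move the number upward. The step from compound 1 to compound 3 is estimated as a 2.5-fold higher number from compound 1 to compound 3 (0.40 log units; beyond the scatter), which is modest but likely beyond the scatter. For compound 3 in this assay the estimate is 1500 nM, with a plausible range from 500 nM to 5000 nM.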

Compound 3, half-maximal inhibitory concentration: 820 nM
Beside the measured number, compound 3's estimate is 1.8-fold (0.26 log units) above it; the range from low to high includes it.
By their numbers in this assay, from the lowest: compounds 1, 3 and 2 (each within the scatter of the next, the first and the last beyond it).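

In this assay, among these compounds, the exchange of phenoxymethyl for cyano on an aromatic carbon, meta to a large group, gives a 1.4-fold higher number from compound 1 to compound 3 (0.14 log units; within the scatter) and is the first step quantified. In this one pair, the outer part of the side chain, including its six-membered aromatic ring, can be removed from this position without a shift that stands clear of the scatter, so phenoxymethyl is not required here for a number of this order on the core of compound 1. Nothing available explains why the two numbers lie so close.

One pair cannot separate a position that is indifferent to its substituent from two unlike groups that happen to give similar numbers; a plain hydrogen, an amine, a carboxylic acid or a longer chain such as phenoxyethyl in the same place would put that to the test. Among the compounds shown here, also open is what the methoxy groups on the core and the link joining the core to this ring contribute, as no step yet touches either.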